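Chain extension on the core of compound 2

The compounds below may be only part of what the source reports. "The series", "measured", "known", "first", "only" and "open" are said of these compounds alone.

Compound 1 `Cc1ccncc1OC[C@@H]1CCCN1C` gives 4.12 nM in an assay on membranes from brain for displacement of a labelled ligand from Neuronal acetylcholine receptor; alpha4/beta2 (Rattus norvegicus); a lower number here means a stronger inhibitor, a higher number a weaker inhibitor.
Compound 2 `Cc1cncc(OC[C@@H]2CCCN2C)c1` gives 0.48 nM in this assay.

Compound 2 holds the lower of the two numbers; compound 1 stands higher by a margin beyond the scatter. Compound 3 `CCCCCCc1cncc(OC[C@@H]2CCCN2C)c1` differs from compound 2 by pentyl in place of hydrogen on a saturated chain carbon bound to an aromatic carbon. Within the data shown here, no measured pair shows a change of this kind, so the size of the step is open. The expectation is that compound 3 comes out weaker, with an estimated step of a 42-fold higher number from compound 2 to compound 3 (1.62 log units; beyond the scatter) that lies beyond the scatter. Compound 3 is estimated at 20 nM, with a range from 3 nM to 150 nM.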

Compound 3, inhibition constant: 0.32 nM
Compound 3: middle estimate off by 63-fold (1.80 log units), on the high side, outside the stated range (below it).
By their numbers in this assay, from the lowest: compounds 3 and 2 (each within the scatter of the next); then compound 1.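

In this assay, pentyl in place of hydrogen on a saturated chain carbon bound to an aromatic carbon gives a 1.5-fold lower number from compound 2 to compound 3 (0.18 log units; within the scatter) and so shows that this position accepts the methyl to hexyl change without a shift beyond the scatter. The earlier compounds shown here gave no reading of chain length at this place. No measured evidence bears on why the number holds here.

As far as these compounds go, whether a longer chain than hexyl keeps the number in this assay stays open. So does the effect of an amine or a carboxylic acid at the chain end.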